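The compounds below may be only part of what the source reports. "The series", "measured", "known", "first", "only" and "open" are said of these compounds alone.

For the measured compounds named here, in a physicochemical assay for lipophilicity, measured as octanol-water partition (a higher number here means a more lipophilic compound, a lower number a more polar compound), compound 1 `CC(C)[C@@H]1CC[C@@H](C)C[C@H]1OC(=O)c1cccc(Cl)c1` gives 5.34, the higher of the two numbers available so far. Compound 2 `CC(C)[C@@H]1CC[C@@H](C)C[C@H]1OC(=O)c1ccc([N+](=O)[O-])cc1` gives 4.78, a gap beyond the usual scatter of such measurements. Still unmeasured is compound 3 `Cc1cccc(C(=O)O[C@@H]2C[C@H](C)CC[C@H]2C(C)C)c1`, which carries methyl in place of chloro on an aromatic carbon, meta to a large group (methyl in place of chloro on an aromatic carbon). Going by the values given here, the two measured compounds differ in more than one place, so no measured step shows what a single change of this kind does. The expectation therefore starts from compound 1 at 5.34 and assumes that the swap moves the number only slightly. A small downward change is expected, estimated as a number 0.14 log units lower from compound 1 to compound 3 (within the scatter), which would stay within the scatter. For compound 3 the expected value is 5.2, with an estimated range of 4.85 to 5.55.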

Compound 3, partition coefficient: 5.29
The estimate for compound 3 lay 0.09 log units below the measured number; the measured number falls inside the stated range.
By their numbers in this assay, from the lowest: compound 2; then compounds 3 and 1 (each within the scatter of the next).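

Methyl in place of chloro on this aromatic carbon, meta to a large group, now has a single-change reading in this assay: the step is a number 0.05 log units lower from compound 1 to compound 3 (within the scatter) and is the only one of its kind among these compounds. At this position of the core of compound 1, this assay therefore does not separate chloro from methyl, something the earlier pair, which differs in more than one place, could not show. No measurement here bears on the reason for this result.

Still open, from the compounds shown here alone, is whether a group of another kind on the same aromatic carbon, such as an amine or a carboxylic acid, would give a step beyond the scatter. Also open, going by these compounds, is whether methyl in place of chloro would give a similar step elsewhere on the six-membered aromatic ring.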